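Isopropyl in Place of Fluoro on the Core of Compound 3

The compounds below may be only part of what the source reports. "The series", "measured", "known", "first", "only" and "open" are said of these compounds alone.

Compound 1, `CC(C)c1ccccc1-c1ccc2[nH]ncc2c1`, gives 514 nM in an assay on CHO-TREX cells for antagonist activity at transient receptor potential cation channel subfamily A member 1 (Homo sapiens), read by FLIPR and calcium flux, with a stated time of 10 min; a higher number here means a weaker inhibitor, a lower number a stronger inhibitor.
Compound 2, `FC(F)c1ccccc1-c1ccc2[nH]ncc2c1`, gives 2200 nM in this assay.
Compound 3, `Fc1cc2[nH]ncc2cc1-c1ccccc1C(F)(F)F`, gives 48 nM in this assay.

Compound 3 shows the lowest number of the three, and its gaps to compound 1 and to compound 2 both lie beyond the scatter. Compound 4, `CC(C)c1cc2[nH]ncc2cc1-c1ccccc1C(F)(F)F`, differs from compound 3 by isopropyl in place of fluoro on an aromatic carbon. For the measured compounds named here, the only measured step, a 4.3-fold higher number from compound 1 to compound 2 (0.63 log units; beyond the scatter), also exchanges an isopropyl, but on the other ring and against difluoromethyl rather than fluoro, so it bears on this change only loosely: it shows that swapping an isopropyl for a small fluorinated group moved the number by a modest amount. For compound 4 a modest rise in this assay is expected, a 3.1-fold higher number from compound 3 to compound 4 (0.49 log units; beyond the scatter), because the gap in the measured step of a 4.3-fold higher number from compound 1 to compound 2 (0.63 log units; beyond the scatter) is the closest guide available. Compound 4 is estimated at 150 nM, within a range from 40 nM to 600 nM.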

Compound 4, half-maximal inhibitory concentration: 25400 nM
Beside the measured number, compound 4's estimate is 170-fold (2.23 log units) below it; measured number outside the range, above it.
By their numbers in this assay, from the lowest: compound 3; then compound 1; then compound 2; then compound 4.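

In this assay, isopropyl in place of fluoro on this aromatic carbon gives a 530-fold higher number from compound 3 to compound 4 (2.72 log units; beyond the scatter), so the group at this position of the shared core can decide most of the reading. The earlier step, a 4.3-fold higher number from compound 1 to compound 2 (0.63 log units; beyond the scatter), pointed the other way and was much smaller: there the number rose when isopropyl left the other ring, whereas here it rises when isopropyl enters, so this pair of steps gives isopropyl no single effect across the series. No measurement shown here explains the jump.

On these data alone, what remains open is how a methyl, a methoxy, a nitrile or an amine would read at this position, and whether any of them would stay near compound 3 at 48 nM. As far as these compounds go, it is also open whether isopropyl here would give a similar rise with another group in place of trifluoromethyl.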